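The compounds below may be only part of what the source reports. "The series", "measured", "known", "first", "only" and "open" are said of these compounds alone.

Compound 1 `Cc1cc(C)cc(-n2nncc2CN2C(=O)C3(C(C#N)=C(N)Oc4c3c3nc5ccccc5nc3c3ccccc43)c3ccccc32)c1` in a functional assay on HCT-116 cells (Homo sapiens) for antiproliferative activity, read by MTT assay, with a stated time of 48 h (on this read-out higher numbers stand for weaker inhibition and lower numbers for stronger inhibition), gives > 50000 nM, a limit of the assay.
Compound 2 `Cc1ccc(Cl)cc1-n1nncc1CN1C(=O)C2(C(C#N)=C(N)Oc3c2c2nc4ccccc4nc2c2ccccc32)c2ccccc21` in this assay gives > 50000 nM, a limit of the assay.
Compound 3 `COc1ccc(-n2nncc2CN2C(=O)C3(C(C#N)=C(N)Oc4c(N)cc5nc6ccccc6nc5c43)c3ccccc32)cc1` in this assay gives > 50000 nM, a limit of the assay.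

Compound 3 therefore stands at the ceiling of what has been recorded, together with the other two measured compounds, as the limit of > 50000 nM in this assay, at which 3 of the 3 values shown sit, shows. Compound 4 `N#CC1=C(N)Oc2c(N)cc3nc4ccccc4nc3c2C12C(=O)N(Cc1cnnn1-c1cc(Cl)ccc1Cl)c1ccccc12` differs from it only by 2,5-dichlorophenyl in place of 4-methoxyphenyl on an aromatic nitrogen. Among the compounds with values here, the one measured step that bears on this kind of change is a step that the two limits leave unreadable from compound 1 to compound 2, and it is also a swap of one aryl group for another on the same aromatic nitrogen. It gives no readable size, so no direction beyond the scatter can be expected. Compound 4 is accordingly expected to remain at the limit, with an estimate of 80000 nM in this assay, in a range from 30000 nM to 300000 nM, so that the step expected is a step that the limit leaves unreadable from compound 3 to compound 4.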

Compound 4, half-maximal inhibitory concentration: > 50000 nM
Compound 4 gave a limit, no number; the forecaster's own chance of this, stated with the estimate: 85%; the middle value does not contradict the limit.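

No step can be read from compound 3 to compound 4, as each gives only a limit of the assay: the limit of > 50000 nM in this assay, at which 4 of the 4 values shown sit.

The compounds shown leave open whether any aryl group on this aromatic nitrogen gives a measurable value.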